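Bis-sulfonamide anilines: a carboxylate swap at the inhibition limit

The compounds below may be only part of what the source reports. "The series", "measured", "known", "first", "only" and "open" are said of these compounds alone.

Compound 1 `CNC(=O)c1ccc(S(=O)(=O)Nc2ccc(NS(=O)(=O)c3ccc(F)cc3)cc2)cc1` — in an assay for inhibition of liver carboxylesterase 1 (Homo sapiens), read by spectrophotometry (on this read-out higher numbers stand for weaker inhibition and lower numbers for stronger inhibition), compound 1 gives > 100000 nM, which is a limit of the assay and not a number.
Compound 2 `Cc1c(C)c(NS(=O)(=O)c2cc(Cl)cc(Cl)c2)c(C)c(C)c1NS(=O)(=O)c1cc(Cl)cc(Cl)c1` — in this assay compound 2 gives > 100000 nM, again a limit rather than a measured number.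
Compound 3 `Cc1cc(C)c(NS(=O)(=O)c2ccccc2)cc1NS(=O)(=O)c1ccccc1` — in this assay compound 3 gives > 100000 nM, also a limit.

Among the measured compounds shown here, all three measured compounds therefore sit at the same place, (the limit of > 100000 nM in this assay, at which 3 of the 3 values shown sit), so compound 1 stands nowhere above or below its companions: no value here separates one from another, and no step between measured compounds can be drawn.

Compound 4 `Cc1ccc(C(=O)O)cc1S(=O)(=O)Nc1ccc(NS(=O)(=O)c2ccc(F)cc2)cc1` is the compound still to be measured. It differs from compound 1 in one place: 5-carboxy-2-methylphenyl in place of 4-(methylcarbamoyl)phenyl on a sulfonyl sulfur. The rest of the shared core of compound 1, with its two sulfonamide links, is kept.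

For the measured compounds named here, since compound 1 gives only a limit in this assay, there is no measured step to lean on. The expectation is that the change brings no step beyond the usual scatter, and that compound 4 is most likely to return a limit as well. The estimate for compound 4 in this assay is 100000 nM, with a range from 30000 nM to 300000 nM, which is expected to mean a step of a number no higher from compound 1 to compound 4 (the limit leaves the size open).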

Compound 4, inhibition constant: > 100000 nM
Compound 4 ended at the assay's limit (the forecaster's own chance of this, stated with the estimate: 80%); the middle value sits exactly at the limit.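

In this assay compound 4 gives > 100000 nM, a limit of the assay and not a number. No step can be read between compound 1 and compound 4, and all four compounds sit together: the limit of > 100000 nM in this assay, at which 4 of the 4 values shown sit.

Whether 5-carboxy-2-methylphenyl differs at all from 4-(methylcarbamoyl)phenyl in inhibition stays open, as does what would bring any of these compounds to a measurable value.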